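A few compounds are considered here, and "the series" means these few. Any claim that something is new, unique, unknown or untested is made for them only; others in the source may bear on it.

Measured so far:
compound 1 `COc1ccc(NC(=O)c2nc(-c3cc(OC)c(OC)c(OC)c3)n(-c3ccc(OC)cc3)n2)cc1`, 99%
compound 2 `COc1ccc(-n2nc(C(=O)Nc3ccc(O)cc3)nc2-c2cc(OC)c(OC)c(OC)c2)cc1`, 74%

In a functional assay on the whole organism for inhibition, with Rattus norvegicus as the target, read by paw edema, with stated times of 30 min and 3 h, at a dose of 0.28 mmol/kg by the oral route (on this read-out higher numbers stand for more inhibition at the one dose given (going by the name of the read-out) and lower numbers for less inhibition), compound 1 gives 99% and compound 2 gives 74%. Among the compounds with values here, compound 2 therefore stands lowest of the two numbers, and its only neighbour is compound 1; the single step measured, a number 25 percentage points lower from compound 1 to compound 2 (beyond the scatter), was a modest drop that went beyond the scatter. Compound 3 `COc1ccc(-n2nc(C(=O)Nc3ccccc3)nc2-c2cc(OC)c(OC)c(OC)c2)cc1` has not yet been measured. It differs from compound 2 in one place: hydrogen in place of hydroxy on an aromatic carbon. Within the data shown here, no measured step matches this change. Among the measured compounds shown here, the one step at hand swapped methyl for hydrogen on the oxygen, whereas here the whole hydroxy group leaves, so that step is only a loose guide and its direction need not carry over. Compound 3 is estimated to come out around 80%, within a range from 55% to 98%. The expected step of a number 6 percentage points higher from compound 2 to compound 3 (within the scatter) is thus small and uncertain.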

Compound 3, a percentage reported as inhibition, in the whole organism at one dose (the size of the read-out at that dose, not a potency): 79%
Compound 3: middle estimate off by 1 percentage points, on the high side; the range from low to high includes it.
By their numbers in this assay, from the lowest: compounds 2 and 3 (each within the scatter of the next); then compound 1.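

Replacing the hydroxy group at this position, para to a large group, with hydrogen gives a number 5 percentage points higher from compound 2 to compound 3 (within the scatter) in this assay, so this read-out does not separate hydroxy from hydrogen here. Replacing methoxy with hydrogen at the same position gives a number 20 percentage points lower from compound 1 to compound 3 (beyond the scatter), a drop much like the one from methoxy to hydroxy, so among these three groups only methoxy stands apart, and a free hydroxy group does no better or worse than no oxygen at all. No measurement at hand offers a reason for this.

The compounds shown leave open whether a longer ether such as ethoxy, or an amine, at this position would side with methoxy or with hydrogen. They also leave open whether these three groups would compare in the same way elsewhere on this ring.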